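The source may hold more compounds than are shown below. What is called first, only, known or untested is meant among the compounds shown, and "the series" means these compounds.

Working notes on the series. The shared core is that of compound 1 `CN(C)/C=N/c1c(C=O)c(-c2ccccc2)nn1-c1ccccc1`, which in a functional assay on NPC-TW01 cells (Homo sapiens) for inhibition, read by MTT assay, with a stated time of 72 h (a lower number here means a stronger inhibitor of growth, a higher number a weaker inhibitor of growth), gives 9300 nM. Compound 2 `CN(C)/C=N/c1c(C=O)c(-c2ccccc2)nn1-c1ccccc1Cl` gives 23300 nM in this assay. Of the two measured compounds, compound 2 stands at the higher number, and the step of a 2.5-fold higher number from compound 1 to compound 2 (0.40 log units; beyond the scatter) lies beyond the scatter. Compound 3 `COc1ccc(-n2nc(-c3ccccc3)c(C=O)c2/N=C/N(C)C)cc1` has not yet been measured. It differs from compound 2 as follows: 4-methoxyphenyl in place of 2-chlorophenyl on an aromatic nitrogen. Going by the values given here, this change is partly the reverse of the one measured step, because a 2.5-fold higher number from compound 1 to compound 2 (0.40 log units; beyond the scatter) records the entry of the chloro that now leaves in compound 3. Among the compounds with values here, the methoxy that enters has no counterpart among the measured compounds, so nothing measured speaks to it. A modest step back toward the number of compound 1 is expected, with a wide range to cover the methoxy. Compound 3 is estimated at 9500 nM in this assay, with a range from 3000 nM to 30000 nM. This estimate means an expected step of a 2.5-fold lower number from compound 2 to compound 3 (0.39 log units; beyond the scatter).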

Compound 3, concentration for 50% growth inhibition: 20200 nM
Estimate against measurement, compound 3: 2.1-fold (0.33 log units) below, and the stated range covers the measured number.
By their numbers in this assay, from the lowest: compound 1; then compounds 3 and 2 (each within the scatter of the next).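

In this assay, 4-methoxyphenyl and 2-chlorophenyl on the aromatic nitrogen are not told apart: the exchange gives a 1.2-fold lower number from compound 2 to compound 3 (0.06 log units; within the scatter), so removing the chloro does not by itself bring the number back toward that of compound 1 when a methoxy enters on the same ring. Set against the unsubstituted phenyl, methoxy in place of hydrogen gives a 2.2-fold higher number from compound 1 to compound 3 (0.34 log units; beyond the scatter), alongside a 2.5-fold higher number from compound 1 to compound 2 (0.40 log units; beyond the scatter), so among these three compounds both substituted phenyls read at higher numbers than the bare phenyl, and none of the three goes against this. Nothing available accounts for this shared shift or for the lack of separation between the two substituted phenyls.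

The chloro and the methoxy differ both in identity and in their place on the phenyl, so the two compounds cannot show which of these matters, or whether any substituent on this ring would give the same reading. Going by these compounds, an amine or a carboxylic acid on this phenyl remains open, as does a longer alkyl chain in place of the whole ring on the aromatic nitrogen.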